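This account rests on a few compounds, and the source may have more. Where it says the series, first, only, none or still open, it means among the compounds named here.

Measured in a functional assay on HepG2 cells (Homo sapiens) for inhibition, read by MTT assay (on this read-out lower numbers stand for stronger inhibition and higher numbers for weaker inhibition), so far
- compound 1 `COc1cc2ncnc(Nc3ccc(NC(=O)c4ccc(F)cc4)cc3)c2cc1OC` gives 15000 nM
- compound 2 `COc1cc2ncnc(Nc3ccc(NC(=O)c4ccc(Cl)c(Cl)c4)cc3)c2cc1OC` gives 28000 nM

Compound 2 lies within the scatter of compound 1, so these two cannot be ranked. Compound 3 `COc1cc2ncnc(Nc3ccc(NC(=O)c4cc(F)ccc4Br)cc3)c2cc1OC` has 2-bromo-5-fluorophenyl in place of 3,4-dichlorophenyl on a carbonyl carbon. For the measured compounds named here, the one measured step that bears on this changed the group at the same place (a 1.9-fold higher number from compound 1 to compound 2 (0.27 log units; within the scatter)) and stayed within the scatter. No step beyond the scatter is therefore expected in this assay, in either direction. The expected step is small (a 1.4-fold lower number from compound 2 to compound 3 (0.15 log units; within the scatter)). For compound 3 the estimated value is 20000 nM, with an expected range from 8000 nM to 50000 nM.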

Compound 3, half-maximal inhibitory concentration: 22000 nM
Compound 3: the middle estimate sits 1.1-fold (0.04 log units) below what was measured, and the stated range covers the measured number.
By their numbers in this assay, from the lowest: compounds 1, 3 and 2 (each within the scatter of the next).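

In this assay, the step to 2-bromo-5-fluorophenyl on the carbonyl carbon is a 1.3-fold lower number from compound 2 to compound 3 (0.10 log units; within the scatter) when it replaces 3,4-dichlorophenyl, and a 1.5-fold higher number from compound 1 to compound 3 (0.17 log units; within the scatter) when it replaces 4-fluorophenyl. All three compounds therefore stay within the scatter of one another, now across three different halogen-bearing phenyl groups, including the first that carries bromine. Nothing available explains this closeness. Still open, on these data alone, is whether an amine or a carboxylic acid on this ring, or a longer chain in its place, would give a step beyond the scatter.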